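A Methyl Group Replaces Fluorine on the Piperazine Aryl Ring

The source may hold more compounds than are shown below. What is called first, only, known or untested is meant among the compounds shown, and "the series" means these compounds.

Of the compounds shown here, three sharing one core have been tested in an assay on brain for inhibition of Fatty-acid amide hydrolase 1 (Rattus norvegicus), read by scintillation counting, with a stated time of 10 min; a lower number here means a stronger inhibitor, a higher number a weaker inhibitor. Compound 1 `CC(C)Cc1ccc(C(C)C(=O)N2CCN(c3ccc(Cl)cc3)CC2)cc1` gives 1700 nM. Compound 2 `CC(C)Cc1ccc(C(C)C(=O)N2CCN(c3ccc(Cl)c(Cl)c3)CC2)cc1` gives 16000 nM. Compound 3 `CC(C)Cc1ccc(C(C)C(=O)N2CCN(c3ccc(F)cc3)CC2)cc1` gives 17000 nM, the highest of the three numbers; it sits within the scatter of compound 2 but is well apart from compound 1, as the step of a 10-fold higher number from compound 1 to compound 3 (1.00 log units; beyond the scatter) shows. The step of a 9.4-fold higher number from compound 1 to compound 2 (0.97 log units; beyond the scatter) shows that a second chloro also raised the number, while a 1.1-fold higher number from compound 2 to compound 3 (0.03 log units; within the scatter) is within the scatter.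

Compound 4 `Cc1cccc(N2CCN(C(=O)C(C)c3ccc(CC(C)C)cc3)CC2)c1` differs from compound 3 in one place: 3-methylphenyl in place of 4-fluorophenyl on an amine nitrogen in a ring. Among the compounds with values here, no measured step involves a methyl group, so the measured steps only show that changing the substituent on this aryl ring can shift the number by sizes such as those in a 9.4-fold higher number from compound 1 to compound 2 (0.97 log units; beyond the scatter) and a 10-fold higher number from compound 1 to compound 3 (1.00 log units; beyond the scatter). The step is expected to be a 2.8-fold lower number from compound 3 to compound 4 (0.45 log units; beyond the scatter), with wide uncertainty. Compound 4 is estimated at 6000 nM, likely between 1500 nM and 25000 nM.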

Compound 4, half-maximal inhibitory concentration: 16000 nM
For compound 4 the middle estimate is 2.7-fold (0.43 log units) below the measured one; low and high end bracket the measured number.
By their numbers in this assay, from the lowest: compound 1; then compounds 2, 4 and 3 (each within the scatter of the next).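

In this assay, 3-methylphenyl on this ring nitrogen gives a number level with that of 4-fluorophenyl (a 1.1-fold lower number from compound 3 to compound 4 (0.03 log units; within the scatter)) and level with that of 3,4-dichlorophenyl (no change at the digits printed from compound 2 to compound 4 (within the scatter)). Against 4-chlorophenyl it stands clearly apart (a 9.4-fold higher number from compound 1 to compound 4 (0.97 log units; beyond the scatter)). A ring carrying only a methyl and no halogen therefore falls in the same range as two halogen-bearing rings, leaving compound 1 as the only one of the four with a lower number, so halogen on this ring does not by itself set the result.

From the compounds shown here alone, whether 4-methylphenyl or 4-bromophenyl would match compound 1 stays open. Nothing at hand accounts for why 4-chlorophenyl alone stands apart.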